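The source may report more compounds than this note shows. Statements on the series, on what has been measured and on what is new or still open speak of the compounds shown alone.

Among the compounds with values here, compound 3 `CN(C)CCCNc1ccnc2cc(OCc3ccc(F)cc3)ccc12` holds the second highest of the three numbers measured so far in a functional assay on NCI-H1650 cells (Homo sapiens) for cytotoxicity, read by MTT assay, with a stated time of 48 h; a higher number here means a weaker inhibitor, a lower number a stronger inhibitor: compound 3 gives 940 nM, its nearest neighbour compound 1 `CN(C)CCNc1ccnc2cc(OCc3ccc(F)cc3)ccc12` gives 780 nM, and the furthest, compound 2 `Clc1ccnc2cc(OCc3ccccc3)ccc12`, gives 2720 nM. Within the data shown here, the only step measured between these compounds, a 1.2-fold higher number from compound 1 to compound 3 (0.08 log units; within the scatter), lies within the scatter. Compound 4 `Fc1ccc(COc2ccc3c(Cl)ccnc3c2)cc1` has not yet been measured in this assay. It differs from compound 3 by chloro in place of (3-(dimethylamino)propyl)amino on an aromatic carbon. Among the measured compounds shown here, no measured step matches this exchange directly; the step from compound 1 to compound 3 only reshapes the amine chain and says little about its removal. What bears on it is compound 2, which carries a chloro on the same aromatic carbon and gives 2720 nM, a number beyond the scatter above that of compound 3. On that basis a rise in the number is expected, a 2.7-fold higher number from compound 3 to compound 4 (0.42 log units; beyond the scatter). Compound 4 is therefore estimated at 2500 nM, with a range from 1200 nM to 5500 nM.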

Compound 4, half-maximal inhibitory concentration: 2230 nM
Compound 4: middle estimate off by 1.1-fold (0.05 log units), on the high side, within the range that was stated.
By their numbers in this assay, from the lowest: compounds 1 and 3 (each within the scatter of the next); then compounds 4 and 2 (each within the scatter of the next).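

Chloro in place of (3-(dimethylamino)propyl)amino on the aromatic carbon opposite the ring nitrogen gives a 2.4-fold higher number from compound 3 to compound 4 (0.38 log units; beyond the scatter) in this assay, and chloro in place of (2-(dimethylamino)ethyl)amino gives a 2.9-fold higher number from compound 1 to compound 4 (0.46 log units; beyond the scatter), so both amine chains on this carbon go with a lower number than chloro. Fluoro in place of hydrogen on an aromatic carbon gives a 1.2-fold lower number from compound 2 to compound 4 (0.09 log units; within the scatter), leaving the two chloro compounds within the scatter of each other whether or not the fluoro is present. Nothing available gives a reason for these steps.

The compounds shown leave open whether the steps follow the nitrogen attached to the aromatic carbon or the terminal dimethylamino. A plain amino group, a chain ending in hydroxyl, or a longer chain on this carbon would bear on that question.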